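Working notes: chloro in place of fluoro in compound 3

The source may report more compounds than this note shows. Statements on the series, on what has been measured and on what is new or still open speak of the compounds shown alone.

compound 1 `COc1cc(NC(C)CCCNC(=O)Nc2cccc(Cl)c2)c2ncccc2c1`: 17000 nM
compound 2 `COc1cc(NC(C)CCCNC(=O)Nc2ccc(Br)cc2)c2ncccc2c1`: 18000 nM
compound 3 `COc1cc(NC(C)CCCNC(=O)NNC(=O)Nc2ccc(F)cc2)c2ncccc2c1`: 104000 nM

All three values come from a functional assay on L1210 cells (Mus musculus) for inhibition, read by MTT assay, with a stated time of 72 h; a lower number here means a stronger inhibitor, a higher number a weaker inhibitor. Compound 3 gives 104000 nM, the highest number of the three, which makes it the weakest inhibitor in this small set. Its distance from the other two is shown by a 6.1-fold higher number from compound 1 to compound 3 (0.79 log units; beyond the scatter) and a 5.8-fold higher number from compound 2 to compound 3 (0.76 log units; beyond the scatter).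

The next compound to be measured is compound 4 `COc1cc(NC(C)CCCNC(=O)NNC(=O)Nc2ccc(Cl)cc2)c2ncccc2c1`. It differs from compound 3 in one place: chloro in place of fluoro on an aromatic carbon. In words, this is chloro in place of fluoro on an aromatic carbon, so that 4-fluorophenyl becomes 4-chlorophenyl.

Within the data shown here, no measured pair isolates this exchange. The nearest evidence is the change from 3-chlorophenyl to 4-bromophenyl, a 1.1-fold higher number from compound 1 to compound 2 (0.02 log units; within the scatter). The two larger steps bear on it less, since each replaces the aryl group with ((4-fluorophenyl)carbamoyl)amino rather than exchanging one halogen for another. No step beyond the scatter is therefore expected in this assay. The expected change is a 1.2-fold lower number from compound 3 to compound 4 (0.09 log units; within the scatter). For compound 4 the estimated value is 85000 nM, with an expected range from 45000 nM to 140000 nM.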

Compound 4, half-maximal inhibitory concentration: 58000 nM
Compound 4: middle estimate off by 1.5-fold (0.17 log units), on the high side; measured number inside the range.
By their numbers in this assay, from the lowest: compounds 1 and 2 (each within the scatter of the next); then compounds 4 and 3 (each within the scatter of the next).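

Notes on the halogen position: in this assay, the exchange of fluoro for chloro on the aromatic carbon para to a large group gives a 1.8-fold lower number from compound 3 to compound 4 (0.25 log units; within the scatter), the first direct reading of a halogen exchange at this position, and it stays within the scatter. The ((4-chlorophenyl)carbamoyl)amino group also stands apart from the two simpler aryl groups, with a 3.2-fold higher number from compound 2 to compound 4 (0.51 log units; beyond the scatter) and a 3.4-fold higher number from compound 1 to compound 4 (0.53 log units; beyond the scatter), so the separation beyond the scatter seen with the ((4-fluorophenyl)carbamoyl)amino group in compound 3 is also seen with a second halogen, although both steps are modest. No measurement available here accounts for either the halogen result or the separation between the two kinds of side chain.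

The compounds shown leave open whether a group other than a halogen at the same aromatic carbon, such as a nitrile, an amine or a carboxylic acid, would give a step beyond the scatter on the ((4-halophenyl)carbamoyl)amino side chain. They also leave open how a longer chain between the shared core and the amide-type nitrogen would read in this assay.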